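Methoxy to hydroxy on compound 2

The source may hold more compounds than are shown below. What is called first, only, known or untested is meant among the compounds shown, and "the series" means these compounds.

In a functional assay on HeLa cells (Homo sapiens) for antiproliferative activity, read by MTT assay, with a stated time of 48 h (on this read-out higher numbers stand for weaker inhibition of growth and lower numbers for stronger inhibition of growth), compound 2 (`COC(=O)N1N=C(c2cccc(OC)c2)CC1c1cc(OC)c(OC)c(OC)c1`) gives 1530 nM and compound 1 (`COC(=O)N1N=C(c2ccccc2)CC1c1cc(OC)c(OC)c(OC)c1`) gives 2180 nM, two values within the scatter of each other. Compound 3 (`CCCOC(=O)N1N=C(c2cccc(OC)c2)CC1c1cc(OC)c(OC)c(OC)c1`) gives > 10000 nM, which is a limit of this assay. Compound 4 (`COC(=O)N1N=C(c2cccc(O)c2)CC1c1cc(OC)c(OC)c(OC)c1`) carries hydrogen in place of methyl on an oxygen on an aromatic ring, methoxy to hydroxy (hydrogen in place of methyl on an oxygen on an aromatic ring). The closest measured change is a 1.4-fold lower number from compound 1 to compound 2 (0.15 log units; within the scatter), which involves the same methoxy and stays small. The other change, an at least 6.5-fold higher number from compound 2 to compound 3 (0.81 log units; beyond the scatter), lies elsewhere in the molecule and bears little on this one. The expected step is therefore small: a 1.6-fold higher number from compound 2 to compound 4 (0.21 log units; within the scatter), slightly towards a higher number and probably within the scatter. For compound 4 the estimate is 2500 nM, with an expected range from 900 nM to 7500 nM.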

Compound 4, concentration for 50% growth inhibition: 1970 nM
Beside the measured number, compound 4's estimate is 1.3-fold (0.10 log units) above it, within the range that was stated.
By their numbers in this assay, from the lowest: compounds 2, 4 and 1 (each within the scatter of the next). At a limit, above all of these: compound 3.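

In this assay, going by these compounds alone, replacing methoxy with hydroxy gives a 1.3-fold higher number from compound 2 to compound 4 (0.11 log units; within the scatter), so this position, earlier seen only with hydrogen and methoxy, also accommodates hydroxy. Hydroxy in place of hydrogen on the aromatic carbon gives a 1.1-fold lower number from compound 1 to compound 4 (0.04 log units; within the scatter), which leaves hydrogen, methoxy and hydroxy here all within the scatter of one another. Nothing shown gives a reason for this flat response.

On these data alone, whether an amine, a carboxylic acid or a longer alkoxy chain on this aromatic carbon would stay as close remains open. So does whether any group here can move the number beyond the scatter.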